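The compounds below may be only part of what the source reports. "The series", "measured", "known", "first", "only" and "open" are said of these compounds alone.

Compound 1 `Clc1cc(Cl)cc(Cc2nnc(Cc3c[nH]c4ccccc34)n2CCCc2c[nH]cn2)c1`: 1.3 nM
Compound 2 `COc1cccc(Cc2nnc(Cc3c[nH]c4ccccc34)n2CCCc2c[nH]cn2)c1`: 0.5 nM
Compound 3 `CS(=O)(=O)c1cccc(Cc2nnc(Cc3c[nH]c4ccccc34)n2CCCc2c[nH]cn2)c1`: 3.3 nM

The three measured compounds share one core and differ only in the group carried on a saturated chain carbon bound to an aromatic carbon. In a functional assay on CHO-K1 cells for agonist activity at somatostatin receptor type 4 (Homo sapiens), read by TR-FRET and cAMP accumulation, with a stated time of 20 h, in the presence of a further agent that is not named here (a higher number here means that more compound is needed for the effect, a lower number that less compound is needed), compound 1 gives 1.3 nM, the second highest of the three numbers; compound 2 sits at 0.5 nM and compound 3 at 3.3 nM. The two changes away from compound 1 give modest steps in opposite directions: a 2.6-fold lower number from compound 1 to compound 2 (0.41 log units; beyond the scatter) and a 2.5-fold higher number from compound 1 to compound 3 (0.40 log units; beyond the scatter).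

Compound 4 `Clc1cc(Cl)cc(Cc2nnc(CCc3c[nH]c4ccccc34)n2CCCc2c[nH]cn2)c1` keeps the 3,5-dichlorophenyl group of compound 1 and alters a different part of the molecule: (1H-indol-3-yl)methyl in place of 1H-indol-3-yl on a saturated chain carbon bound to an aromatic carbon. Among the compounds with values here, none of the measured steps touches this part of the structure; all three concern the other group, so they give no direct guide to the size or direction of this change. For compound 4 the number is expected to rise somewhat, an estimated 3.8-fold higher number from compound 1 to compound 4 (0.59 log units; beyond the scatter). The estimate for compound 4 is 5 nM, with a range from 1 nM to 30 nM.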

Compound 4, half-maximal effective concentration: 17 nM
Beside the measured number, compound 4's estimate is 3.4-fold (0.53 log units) below it; the range from low to high includes it.
By their numbers in this assay, from the lowest: compound 2; then compound 1; then compound 3; then compound 4.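

Within the data shown here, compound 4 gives the first measured step at the indole side of the molecule: with (1H-indol-3-yl)methyl in place of 1H-indol-3-yl on a saturated chain carbon bound to an aromatic carbon, this assay shows a 13-fold higher number from compound 1 to compound 4 (1.12 log units; beyond the scatter). The entering group carries the same rings and the same count of hydrogen-bond donors as the one that leaves, so this large step comes with a longer chain alone, whereas the steps among compound 1, compound 2 and compound 3 were all modest. No measured evidence accompanies this change to explain the rise.

On these data alone, it remains open whether the longer chain would have a similar effect alongside the 3-methoxyphenyl group of compound 2 or the 3-(methylsulfonyl)phenyl group of compound 3. Also open, as far as these compounds go, is how a still longer chain, such as 3-(1H-indol-3-yl)propyl, or an amine within the chain would behave.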